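Removing the Butyl Group from Compound 2

The source may hold more compounds than are shown below. What is called first, only, known or untested is meant among the compounds shown, and "the series" means these compounds.

Among the compounds with values here, the series rests on a shared core carrying a triazolylmethyl side chain, and the three measured members differ only in the substituent on that ring. Compound 1 `O=C1O[C@H]([C@@H](O)Cn2cc(-c3cc(C(F)(F)F)cc(C(F)(F)F)c3)nn2)C(OCc2ccccc2)=C1OCc1ccccc1` gives 28900 nM in a functional assay on A549 cells (Homo sapiens) for antiproliferative activity, read by MTT assay, with a stated time of 72 h; on this read-out higher numbers stand for weaker inhibition and lower numbers for stronger inhibition. Compound 2 `CCCCc1cn(C[C@H](O)[C@H]2OC(=O)C(OCc3ccccc3)=C2OCc2ccccc2)nn1` gives 28600 nM in this assay, a number that stands second highest of the three and within the scatter of compound 1. Compound 3 `Cc1ccc(-c2cn(C[C@H](O)[C@H]3OC(=O)C(OCc4ccccc4)=C3OCc3ccccc3)nn2)cc1` gives 8690 nM, and the step of a 3.3-fold lower number from compound 2 to compound 3 (0.52 log units; beyond the scatter) is the only one beyond the scatter. The unmeasured compound 4 `O=C1O[C@H]([C@@H](O)Cn2ccnn2)C(OCc2ccccc2)=C1OCc1ccccc1` differs from compound 2 by hydrogen in place of butyl on an aromatic carbon. Within the data shown here, no measured pair bears on this change directly: the single informative step replaces butyl with 4-methylphenyl, and nothing shows what losing the substituent altogether does. Compound 1 and compound 2 show that two very different groups at this position give the same number, so compound 4 is expected to land near compound 2, with a 1.2-fold higher number from compound 2 to compound 4 (0.09 log units; within the scatter) not beyond the scatter. Compound 4 is therefore estimated at 35000 nM, within 15000 nM to 80000 nM.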

Compound 4, half-maximal inhibitory concentration: > 100000 nM
Compound 4: only a limit was reported; the forecaster's own chance of this, stated with the estimate: 10%; at least 2.8-fold (0.45 log units) between middle value and limit.
By their numbers in this assay, from the lowest: compound 3; then compounds 2 and 1 (each within the scatter of the next). At a limit, above all of these: compound 4.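

The earlier compounds shown here only exchanged one group for another on this aromatic carbon of the five-membered ring; this change removes the group altogether, and the effect is beyond the scatter whichever group leaves. Hydrogen in place of butyl gives an at least 3.4-fold higher number from compound 2 to compound 4 (0.54 log units; beyond the scatter), and hydrogen in place of 4-methylphenyl gives an at least 11-fold higher number from compound 3 to compound 4 (1.06 log units; beyond the scatter), so among the compounds shown, each of those with a group here has a measured number, while the one bearing only hydrogen does not. Compound 4 is reported only as a limit, so its true distance from the others stays unknown: the limit of > 100000 nM in this assay, at which 1 of the 4 values shown sits.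

The compounds shown leave open how small a group on this carbon can be before the number is lost, as a methyl or an ethyl chain would show. They also leave open whether a longer chain, an amine or a carboxylic acid here would match butyl or 4-methylphenyl.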